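The compounds below may be only part of what the source reports. "The series", "measured", "known", "first", "only" and "open" are said of these compounds alone.

Measured so far:
compound 1 `O=C(Nc1cccc(CNc2nccnc2Cl)c1)NC1CCCCC1` — in a functional assay on HepG2 cells (Homo sapiens) for antiproliferative activity, read by MTT assay, with a stated time of 48 h (a lower number here means a stronger inhibitor, a higher number a weaker inhibitor), compound 1 gives only a limit, > 40000 nM.
compound 2 `Cc1ccccc1NC(=O)Nc1cccc(CNc2nccnc2Cl)c1` — in this assay compound 2 gives 15300 nM.
compound 3 `CN(C)c1ccc(NC(=O)Nc2cccc(CNc3nccnc3Cl)c2)cc1` — in this assay compound 3 gives only a limit, > 40000 nM.

Compound 3 therefore sits at the limit of > 40000 nM in this assay, at which 2 of the 3 values shown sit, and carries no number of its own. Compound 4 `COc1ccccc1NC(=O)Nc1cccc(CNc2nccnc2Cl)c1` differs from compound 3 by 2-methoxyphenyl in place of 4-(dimethylamino)phenyl on an amide-type nitrogen. Within the data shown here, the steps that bear on this are an at least 2.6-fold higher number from compound 2 to compound 3 (0.41 log units; beyond the scatter), where the 2-methylphenyl of compound 2 is the nearest kin of the incoming 2-methoxyphenyl, and an at least 2.6-fold lower number from compound 1 to compound 2 (0.41 log units; beyond the scatter). Both favour a return toward the number seen for compound 2, so a modest lowering from the limit is expected, an at least 2.0-fold lower number from compound 3 to compound 4 (0.30 log units; that floor lies within the scatter), though a second limit cannot be excluded. Compound 4 is estimated at 20000 nM, within 8000 nM to 50000 nM.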

Compound 4, half-maximal inhibitory concentration: 13700 nM
Beside the measured number, compound 4's estimate is 1.5-fold (0.16 log units) above it; measured number inside the range.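

On the amide-type nitrogen, 2-methoxyphenyl gives a readable number in this assay, with an at least 2.9-fold lower number from compound 3 to compound 4 (0.46 log units; beyond the scatter) and an at least 2.9-fold lower number from compound 1 to compound 4 (0.46 log units; beyond the scatter). The 2-methylphenyl and 2-methoxyphenyl groups cannot be told apart here, with methoxy in place of methyl giving a 1.1-fold lower number from compound 2 to compound 4 (0.05 log units; within the scatter). Compound 1 and compound 3 remain limits, not numbers: the limit of > 40000 nM in this assay, at which 2 of the 4 values shown sit.

Open, as far as these compounds go, is whether the substituent's place on the phenyl ring or its kind decides the result, a question that 4-methoxyphenyl on the same nitrogen would address. Also open, from the compounds shown here alone, is how unsubstituted phenyl, 2-chlorophenyl or 2-aminophenyl would read in this assay.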